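The source may report more compounds than this note shows. Statements on the series, on what has been measured and on what is new or still open speak of the compounds shown alone.

Measured compounds:
Compound 1, `C=CCn1c(=O)/c(=C\c2cccc(F)c2)[nH]c(=O)/c1=C\c1ccccc1OC`, in a functional assay on A549 cells (Homo sapiens) for cytotoxicity, read by CCK-8 assay, with a stated time of 72 h; a higher number here means a weaker inhibitor, a lower number a stronger inhibitor: 19700 nM
Compound 2, `C=CCn1c(=O)/c(=C\c2ccc(F)c(Br)c2)[nH]c(=O)/c1=C\c1ccccc1OC`, in this assay: "not active" (no number reported)

Two compounds share the same core and differ in the aryl group on the double-bonded chain carbon. Compound 1 carries a 3-fluorophenyl group and in this assay compound 1 gives 19700 nM, a weak result. Compound 2 carries a 3-bromo-4-fluorophenyl group and in this assay compound 2 is reported as "not active" (no number reported), so no single number stands for it; it is known only that nothing measurable was seen.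

Compound 3, `C=CCn1c(=O)/c(=C\c2cccc(C)c2)[nH]c(=O)/c1=C\c1ccccc1OC`, is not yet measured. It differs from compound 2 by 3-methylphenyl in place of 3-bromo-4-fluorophenyl on a double-bonded chain carbon bound to an aromatic carbon. Within the data shown here, no step between measured compounds is available to scale this change. With compound 1 weak and compound 2 without a number, the step from compound 2 to compound 3 in this assay is expected to be small or absent, staying in the weak range, with a real chance that again no number is reported. Compound 3 is estimated at 30000 nM, within 8000 nM to 100000 nM.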

Compound 3, half-maximal inhibitory concentration: 22700 nM
Compound 3: the middle estimate sits 1.3-fold (0.12 log units) above what was measured; the measured number falls inside the stated range.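

In this assay, the step of a 1.2-fold higher number from compound 1 to compound 3 (0.06 log units; within the scatter) shows that methyl in place of fluoro on an aromatic carbon leaves the reading unchanged within the scatter, so this aryl group tolerates either substituent without any gain in strength. It also shows that a number can be read with 3-methylphenyl at this place, as compound 3 gives 22700 nM, whereas compound 2, with 3-bromo-4-fluorophenyl, gave none, so the loss of a number is tied to that group rather than to the shared core. No measurement is available here that explains either result.

The compounds shown do not separate the contribution of the bromine from that of the added fluorine in compound 2. They also leave open whether an amine or a carboxylic acid on this aryl group would move the reading out of the weak range.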